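Cyano for Chloro on a Core Without Measurable Activity

This account rests on a few compounds, and the source may have more. Where it says the series, first, only, none or still open, it means among the compounds named here.

Measured so far:
compound 1 `O=[N+]([O-])c1ccc(-c2csc(N3N=C(c4ccc(N5CCCCC5)cc4)CC3c3ccc(Cl)cc3)n2)cc1` — > 100000 nM
compound 2 `Clc1ccc(-c2csc(N3N=C(c4ccc(N5CCCCC5)cc4)CC3c3ccc(Cl)cc3)n2)cc1` — > 100000 nM

In a functional assay on MCF7 cells (Homo sapiens) for antiproliferative activity, read by MTT assay, with a stated time of 72 h (a lower number here means a stronger inhibitor, a higher number a weaker inhibitor), compound 1 reaches only a limit of the assay, > 100000 nM. Compound 2 likewise gives only a limit in this assay, > 100000 nM. The step that the two limits leave unreadable from compound 1 to compound 2 therefore cannot be read, and compound 2 stands at the limit of > 100000 nM in this assay, at which 2 of the 2 values shown sit, with no number of its own.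

Compound 3 `N#Cc1ccc(-c2csc(N3N=C(c4ccc(N5CCCCC5)cc4)CC3c3ccc(Cl)cc3)n2)cc1` differs from compound 2 by cyano in place of chloro on an aromatic carbon. Going by the values given here, the one measured step bears on this change only insofar as an aromatic substituent on the same ring was swapped and both compounds stayed beyond the limit, so the step that the limit leaves unreadable from compound 2 to compound 3 is expected to be no change that can be read. Compound 3 is estimated at 150000 nM, within 40000 nM to 500000 nM, most likely reported again as a limit.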

Compound 3, half-maximal inhibitory concentration: 9760 nM
Compound 3: middle estimate off by 15-fold (1.19 log units), on the high side, outside the stated range (below it).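

In this assay, cyano on this aromatic carbon gives the first readable result in the series: replacing chloro produces an at least 10-fold lower number from compound 2 to compound 3 (1.01 log units; beyond the scatter), and replacing nitro produces an at least 10-fold lower number from compound 1 to compound 3 (1.01 log units; beyond the scatter). The shared core can therefore give a measurable value, and the group at this place, para to a large group, can decide whether it does. Compound 3 is the only one of the three with a number of its own, while compound 1 and compound 2 remain at a limit of the assay: the limit of > 100000 nM in this assay, at which 2 of the 3 values shown sit.

With only three groups shown at this place, no trend can be drawn from them. On these data alone, whether an amine, a carboxylic acid, or a methoxy group here would match cyano remains open, as does the effect of cyano at another place on the ring.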